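Changing the group on the ring amine nitrogen

The compounds below may be only part of what the source reports. "The series", "measured", "known", "first", "only" and "open" are said of these compounds alone.

Compound 3 `COc1ccccc1N1CCN(C(=O)CN2C(=O)CC(C)(c3ccccc3)C2=O)CC1` needs 300 mg/kg in a functional assay on the whole organism (strain CD-1) with Mus musculus as the target, in the maximal electroshock model, with a stated time of 2 h; a lower number here means that less compound is needed, a higher number that more compound is needed for the effect. Compound 1 `CC1(c2ccccc2)CC(=O)N(CC(=O)N2CCN(c3cccc(C(F)(F)F)c3)CC2)C1=O` needs 300 mg/kg, so compound 3 stands level with compound 1 within the scatter. Compound 2 `CC1(c2ccccc2)CC(=O)N(CC(=O)N2CCN(c3ccccc3)CC2)C1=O`, which carries a plain phenyl on the ring amine nitrogen, was reported as "not active" (no number reported), with no number given. Compound 4 `CC1(c2ccccc2)CC(=O)N(CC(=O)N2CCN(c3ccc(Cl)c(Cl)c3)CC2)C1=O` differs from compound 3 in one place only: 3,4-dichlorophenyl in place of 2-methoxyphenyl on an amine nitrogen in a ring. Going by the values given here, the single step that bears on this change, no change at the digits printed from compound 1 to compound 3 (within the scatter), shows that trading one substituted phenyl for another left the dose unchanged. The expected step of no change at the digits printed from compound 3 to compound 4 (within the scatter) is therefore none beyond the scatter. Compound 4 is estimated to need 300 mg/kg, with a range from 100 mg/kg to 600 mg/kg. An outcome like that of compound 2 remains possible.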

Compound 4, minimum effective dose: 300 mg/kg
Compound 4: the middle estimate sits on the measured number at the digits printed; the measured number falls inside the stated range.
By their numbers in this assay, from the lowest: compounds 1, 3 and 4 (each within the scatter of the next).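

Putting 3,4-dichlorophenyl on the ring amine nitrogen gives no change at the digits printed from compound 3 to compound 4 (within the scatter) in this assay, and the exchange against 3-(trifluoromethyl)phenyl gives no change at the digits printed from compound 1 to compound 4 (within the scatter) as well. Three differently substituted phenyl groups, carrying methoxy, trifluoromethyl or two chlorines, now stand level at this position, while compound 2, with plain phenyl, goes against any wider pattern, being reported as not active without a number. As far as these compounds go, whether a pyridine ring or a cyclohexyl ring on this nitrogen would stand level with them remains open. Nothing measured here explains the level doses.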